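Amino-linked five-membered heteroaryl in place of imidazolyl

The compounds below may be only part of what the source reports. "The series", "measured", "known", "first", "only" and "open" are said of these compounds alone.

Measured compounds in a functional assay on CHO cells for antagonist activity at prostaglandin E2 receptor EP3 subtype (Homo sapiens), read by cAMP accumulation; a higher number here means a weaker inhibitor, a lower number a stronger inhibitor:
- compound 1 `CC(C)C(c1ccc(-c2ccc3cccc(F)c3c2)[nH]c1=O)N1CCCCS1(=O)=O`: 122 nM
- compound 2 `CC(C)C(Nc1nnc[nH]1)c1ccc(-c2ccc3cccc(F)c3c2)[nH]c1=O`: 185 nM
- compound 3 `Cc1nc(C(c2ccc(-c3ccc4cccc(F)c4c3)[nH]c2=O)C(C)C)[nH]c1C`: 50 nM

Compound 3 gives the lowest number of the three in this assay; its nearest neighbour is compound 1, with a 2.4-fold lower number from compound 1 to compound 3 (0.39 log units; beyond the scatter), and the furthest is compound 2, with a 3.7-fold lower number from compound 2 to compound 3 (0.57 log units; beyond the scatter). Within the data shown here, both of these steps lie beyond the scatter, so compound 3 is the most potent compound measured so far.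

Compound 4 `CC(C)C(Nc1nccs1)c1ccc(-c2ccc3cccc(F)c3c2)[nH]c1=O` carries the change ((1,3-thiazol-2-yl)amino in place of 4,5-dimethyl-1H-imidazol-2-yl on a saturated chain carbon bound to an aromatic carbon and a saturated chain carbon). The new group is, like that of compound 2, a five-membered aromatic ring joined through an amino link, whereas compound 3 has its ring bound directly. The step that bears most on this change is a 3.7-fold lower number from compound 2 to compound 3 (0.57 log units; beyond the scatter), which went in the favourable direction when the amino-linked triazolyl was exchanged for the directly bound dimethylimidazolyl; the reverse sense of that exchange is now made, with a thiazolyl instead of a triazolyl. The step of a 1.5-fold higher number from compound 1 to compound 2 (0.18 log units; within the scatter), within the scatter, shows that an amino-linked five-membered ring sits close to the sulfonyl-containing six-membered ring of compound 1. A modest rise in the number is therefore expected, in the order of a 3.0-fold higher number from compound 3 to compound 4 (0.48 log units; beyond the scatter). Compound 4 is estimated at 150 nM in this assay, within a range of 60 nM to 400 nM.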

Compound 4, half-maximal inhibitory concentration: 10 nM
Estimate against measurement, compound 4: 15-fold (1.18 log units) above, outside the stated range (below it).
By their numbers in this assay, from the lowest: compound 4; then compound 3; then compounds 1 and 2 (each within the scatter of the next).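

In this assay an amino link on this saturated chain carbon carries no penalty of its own: (1,3-thiazol-2-yl)amino outperforms the directly bound 4,5-dimethyl-1H-imidazol-2-yl (a 5.0-fold lower number from compound 3 to compound 4 (0.70 log units; beyond the scatter)), so the earlier gap between compound 2 and compound 3 cannot be read as a general cost of the amino link. With that link held constant, the identity of the ring on the amine nitrogen decides the outcome, and 1,3-thiazol-2-yl in place of 4H-1,2,4-triazol-3-yl gives the largest step in the set (a 19-fold lower number from compound 2 to compound 4 (1.27 log units; beyond the scatter)). Amino-linked rings are also not interchangeable relative to the six-membered non-aromatic ring of compound 1: compound 2 stays within the scatter of compound 1, whereas the thiazolyl compound separates clearly (a 12-fold lower number from compound 1 to compound 4 (1.09 log units; beyond the scatter)) and is the most potent of the four.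

No measurement shown here explains why the thiazolyl and triazolyl rings differ so widely. On these data alone, it remains open how a 1,3-oxazol-2-yl group on the amine nitrogen, a methyl group on the thiazole ring or a directly bound 1,3-thiazol-2-yl group would compare.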